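The source may report more compounds than this note shows. Statements on the series, on what has been measured and on what is new or still open speak of the compounds shown alone.

In a functional assay on PC-3 cells (Homo sapiens) for antiproliferative activity, read by MTT assay, with a stated time of 72 h (a higher number here means a weaker inhibitor, a lower number a stronger inhibitor), compound 1 `C=C(C)C(=O)Nc1cc2c(N3CCc4ccccc43)ncnc2cc1OC` gives 4830 nM, the lowest of the three numbers measured, although the other two lie within the scatter of it, so no real ranking follows. Compound 2 `C=C(C)C(=O)Nc1cc2c(N3CCc4ccccc43)ncnc2cc1O[C@@H]1CCOC1` gives 4910 nM in this assay, and compound 3 `C/C=C/C(=O)Nc1cc2c(N3CCCc4ccccc43)ncnc2cc1OC` gives 7520 nM. For the measured compounds named here, the only single change measured so far, a 1.0-fold higher number from compound 1 to compound 2 (0.01 log units; within the scatter), exchanges the group on the aromatic oxygen and leaves the number essentially where it was.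

Compound 4 `COc1cc2ncnc(N3CCc4ccccc43)c2cc1NC(=O)/C=C/CN1CCCC1` has not yet been measured. It differs from compound 1 by 3-(pyrrolidin-1-yl)prop-1-en-1-yl in place of 1-methylethenyl on a carbonyl carbon. Going by the values given here, no measured pair isolates this change. Compound 3 carries a different group on the same carbonyl carbon, but also a different saturated ring on the core, so its value and that of compound 1 only show that the two compounds sit within the scatter of each other. Among the compounds with values here, the one measured step concerns another part of the molecule and says nothing about the carbonyl substituent.

Within the data shown here, with no comparable step to lean on, the expected change is estimated as a 1.6-fold lower number from compound 1 to compound 4 (0.21 log units; within the scatter), given with a wide range. Compound 4 is therefore expected to give 3000 nM in this assay, somewhere between 900 nM and 10000 nM.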

Compound 4, half-maximal inhibitory concentration: 2620 nM
Compound 4: the middle estimate sits 1.1-fold (0.06 log units) above what was measured, and the stated range covers the measured number.
By their numbers in this assay, from the lowest: compounds 4, 1, 2 and 3 (each within the scatter of the next, the first and the last beyond it).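

For the compounds shown here, the exchange at this carbonyl carbon is the first measured change in the group on the amide carbonyl with the rest of the molecule held constant. It replaces 1-methylethenyl, with 3 heavy atoms and no ring, by 3-(pyrrolidin-1-yl)prop-1-en-1-yl, with 8 heavy atoms and a five-membered non-aromatic ring containing one nitrogen. In this assay, this much larger group gives a 1.8-fold lower number from compound 1 to compound 4 (0.27 log units; within the scatter), so the antiproliferative reading in these cells stays within the scatter even with this added bulk and nitrogen, and no real gain can be claimed. No measurement of any property of these two groups is available to account for the size of this step.

The compounds shown leave open whether the ring nitrogen matters at all, a question that a cyclopentyl ring or a dimethylamino group in place of the pyrrolidine would help to separate from the effect of size alone. They also leave open whether the same exchange would give a similar step on the oxolan-3-yl ether of compound 2.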